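Working notes: fluoro in place of cyano, compound 3

This account rests on a few compounds, and the source may have more. Where it says the series, first, only, none or still open, it means among the compounds named here.

Two compounds of the series carry numbers in an assay on isolated protein for inhibition of Aromatase (Homo sapiens), read by fluorescence; on this read-out higher numbers stand for weaker inhibition and lower numbers for stronger inhibition. Compound 1 `Cc1cc(S(=O)(=O)N2CCCC(Cn3ccnc3)C2)ccc1F` gives 24 nM in this assay. Compound 2 `N#Cc1ccc(S(=O)(=O)N2CCCC(Cn3ccnc3)C2)cc1` gives 36 nM in this assay, the higher of the two numbers, though its gap to compound 1 lies within the scatter, so the two cannot be ordered on what is shown.

Compound 3 `O=S(=O)(c1ccc(F)cc1)N1CCCC(Cn2ccnc2)C1` has not been measured. It differs from compound 2 in one place: fluoro in place of cyano on an aromatic carbon. For the measured compounds named here, no pair of measured compounds covers this change, so the series holds no precedent for it. Going by the values given here, the only guidance is that compound 1, which also carries a fluoro on its six-membered aromatic ring of carbon only, gives 24 nM in this assay, a number close to that of compound 2.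

The change is expected to produce a step of a 1.3-fold higher number from compound 2 to compound 3 (0.10 log units; within the scatter) in this assay, a shift no larger than the scatter and without a clear direction. Compound 3 is therefore estimated at about 45 nM in this assay, within a range from 18 nM to 120 nM.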

Compound 3, half-maximal inhibitory concentration: 51 nM
Compound 3: middle estimate off by 1.1-fold (0.05 log units), on the low side; measured number inside the range.
By their numbers in this assay, from the lowest: compounds 1, 2 and 3 (each within the scatter of the next, the first and the last beyond it).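

In this assay, fluoro in place of cyano on the aromatic carbon para to a large group gives a 1.4-fold higher number from compound 2 to compound 3 (0.15 log units; within the scatter), so the two groups cannot be told apart at this position on this read-out, even though the change removes the triple bond and the hydrogen-bond acceptor counted for cyano. Hydrogen in place of methyl on an aromatic carbon gives a 2.1-fold higher number from compound 1 to compound 3 (0.33 log units; beyond the scatter), the only step shown that lies beyond the scatter, and it is modest; with fluoro held constant, the methyl on the ring therefore makes a measurable difference where the swap of cyano for fluoro does not. Nothing measured bears on why either step has the size it does.

From the compounds shown here alone, each step rests on a single pair, so it remains open whether the methyl step would carry over with cyano in place of fluoro. Going by these compounds, it also remains open whether a larger or charged group at the same place, such as a methoxy, an amine or a carboxylic acid, would stay within the scatter of compound 2 or move the number beyond it.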